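The source may hold more compounds than are shown below. What is called first, only, known or untested is meant among the compounds shown, and "the series" means these compounds.

Measured so far in a functional assay on NCI-H522 cells (Homo sapiens) for inhibition, read by CellTiter-Glo, with a stated time of 48 h, in the presence of a further agent that is not named here; on this read-out lower numbers stand for stronger inhibition of growth and higher numbers for weaker inhibition of growth:

- compound 1 `C#CCCCC(=O)Nc1ccc(C(=O)c2ccc(Nc3ncc(F)c(Nc4ccccc4NS(C)(=O)=O)n3)cc2)cc1`: 2900 nM
- compound 2 `CS(=O)(=O)Nc1ccccc1Nc1nc(Nc2ccc(C(=O)OCc3ccccc3)cc2)ncc1F`: 16500 nM
- compound 3 `CS(=O)(=O)Nc1ccccc1Nc1nc(Nc2ccc(Oc3ccccc3)cc2)ncc1F`: 7300 nM

In this assay compound 3 stands second highest of the three numbers, below compound 2 and above compound 1, with both gaps beyond the scatter. The next compound to be read is compound 4 `CS(=O)(=O)Nc1ccccc1Nc1nc(Nc2ccc(Cl)cc2)ncc1F`, which carries chloro in place of phenoxy on an aromatic carbon, para to a large group: chloro in place of phenoxy on an aromatic carbon.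

Going by the values given here, only one measured step bears on this change: a 2.3-fold lower number from compound 2 to compound 3 (0.35 log units; beyond the scatter), a modest step that also exchanges the group on this aromatic carbon. Among the compounds with values here, compound 1 differs from the others in more than one place and gives no clean step. Within the data shown here, no measured compound carries a group as small as chloro here, so the direction remains open and the range is kept wide.

The expected change is a 1.2-fold higher number from compound 3 to compound 4 (0.09 log units; within the scatter), which means no expected step beyond the scatter. For compound 4 the estimated value is 9000 nM, with an expected range from 3500 nM to 23000 nM.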

Compound 4, concentration for 50% growth inhibition: 12200 nM
Estimate against measurement, compound 4: 1.4-fold (0.13 log units) below; low and high end bracket the measured number.
By their numbers in this assay, from the lowest: compound 1; then compounds 3, 4 and 2 (each within the scatter of the next, the first and the last beyond it).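

In this assay, chloro in place of phenoxy on this aromatic carbon, para to a large group, gives a step that stays within the scatter (a 1.7-fold higher number from compound 3 to compound 4 (0.22 log units; within the scatter)), so the six-membered aromatic ring of phenoxy is not needed here to hold the read-out within that range. Chloro in place of benzyloxycarbonyl also stays within the scatter (a 1.4-fold lower number from compound 2 to compound 4 (0.13 log units; within the scatter)), which places compound 4 within the scatter of both compound 2 and compound 3, even though those two lie beyond the scatter of each other, so the three groups give no clear order by size. Nothing measured here speaks to the reason for these small steps.

From the compounds shown here alone, whether any group at this position gives a larger step remains open. An amine, a carboxylic acid or a longer chain on this carbon would test that.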